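The source may hold more compounds than are shown below. What is called first, only, known or untested is meant among the compounds shown, and "the series" means these compounds.

Measured compounds:
compound 1 `COc1ccc(-c2ccc(-c3ccc(C(=N)N)o3)o2)cc1` — 2430 nM
compound 2 `N=C(N)c1ccc(-c2ccc(-c3cncc4ccccc34)s2)s1` — 1710 nM
compound 3 `N=C(N)c1ccc(-c2ccc(-c3ccc4ccccc4c3)s2)s1` — 1810 nM

These three values come from a functional assay on OVCAR-5 cells (Homo sapiens) for inhibition, read by sulforhodamine B assay, with a stated time of 48 h; on this read-out lower numbers stand for stronger inhibition of growth and higher numbers for weaker inhibition of growth. Compound 1 gives the largest of the three numbers, yet its gaps to compound 3 and to compound 2 both lie within the scatter, so the three compounds cannot be told apart in this assay . The unmeasured compound 4 `N=C(N)c1ccc(-c2ccc(-c3ccc(F)cc3)o2)o1` differs from compound 1 in one place: fluoro in place of methoxy on an aromatic carbon. Among the measured compounds shown here, no step between two measured compounds is known here, so nothing shows how such a swap plays out. The change is small, and the expected step is a 1.0-fold higher number from compound 1 to compound 4 (0.01 log units; within the scatter), not beyond the scatter in either direction. Compound 4 is therefore estimated at 2500 nM, with a range from 1000 nM to 6500 nM.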

Compound 4, concentration for 50% growth inhibition: 1660 nM
Compound 4: the middle estimate sits 1.5-fold (0.18 log units) above what was measured, within the range that was stated.
By their numbers in this assay, from the lowest: compounds 4, 2, 3 and 1 (each within the scatter of the next).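

In this assay, placing fluoro instead of methoxy on this aromatic carbon, para to a large group, gives a 1.5-fold lower number from compound 1 to compound 4 (0.17 log units; within the scatter), so the number does not separate the two groups. This is the only one-place comparison among the compounds shown, and it indicates that this exchange at this position leaves growth inhibition within the usual variation between repeats. Nothing available here explains the result.

From the compounds shown here alone, whether an amine or a carboxylic acid on this same carbon would move the number beyond the scatter remains open. So does whether fluoro in place of methoxy would behave alike on a different core.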